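A few compounds are considered here, and "the series" means these few. Any claim that something is new, unique, unknown or untested is made for them only; others in the source may bear on it.

Measured in a functional assay on U-937 cells (Homo sapiens) for antiproliferative activity, read by MTT assay, with a stated time of 72 h (a higher number here means a weaker inhibitor, a lower number a stronger inhibitor), so far:
- compound 1 `O=C(CCCCCCc1nc(-c2ccccc2Cl)no1)NO` gives 750 nM
- compound 2 `O=C(CCCCCCc1nc(-c2cccnc2)no1)NO` gives 350 nM
- compound 3 `Nc1ccccc1NC(=O)CCCCCCc1nc(-c2ccccc2)no1` gives 730 nM

Compound 3 at 730 nM sits within the scatter of compound 1 at 750 nM and so shares the upper end of this small set, while compound 2 at 350 nM stands lower.

Compound 4 `Nc1ccccc1NC(=O)CCCCCCc1nc(-c2ccc(Cl)cc2)no1` comes from compound 3 by one change: chloro in place of hydrogen on an aromatic carbon, phenyl to 4-chlorophenyl (chloro in place of hydrogen on an aromatic carbon).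

Within the data shown here, only one measured step is available, a 2.1-fold lower number from compound 1 to compound 2 (0.33 log units; beyond the scatter), and it is modest. It bears only loosely here, as it exchanges pyridin-3-yl in place of 2-chlorophenyl rather than adding a chloro to a phenyl. Compounds 1 and 2 also carry a different end group on the chain from compound 3. Among the measured compounds shown here, no measured pair shows chloro in place of hydrogen, so neither a direction nor a size is supported by the data, and a small step is the cautious expectation in this assay. The estimated step is a 1.0-fold lower number from compound 3 to compound 4 (0.02 log units; within the scatter), so no change beyond the scatter is expected. For compound 4 the expected value is 700 nM, with an estimated range of 300 nM to 1600 nM.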

Compound 4, half-maximal inhibitory concentration: 4360 nM
Beside the measured number, compound 4's estimate is 6.2-fold (0.79 log units) below it; measured number outside the range, above it.
By their numbers in this assay, from the lowest: compound 2; then compounds 3 and 1 (each within the scatter of the next); then compound 4.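

In this assay, among these compounds, the aromatic ring of this series proves sensitive to substitution: chloro in place of hydrogen, on an aromatic carbon para to a large group, gives a 6.0-fold higher number from compound 3 to compound 4 (0.78 log units; beyond the scatter) in the only measured pair for this change. A single added heavy atom at this place is therefore enough to produce a weaker inhibitor, so the place cannot be treated as tolerant of substitution, although this rests on one pair carrying the end group shared by compound 3 and compound 4. No data available here bear on why the step takes this direction or size.

The compounds shown leave open whether the step belongs to chloro specifically or to any substituent at this place, a question that fluoro, methyl, methoxy or an amine at the same carbon would help to settle. From the compounds shown here alone, it also remains open whether the same change would give a similar step with the different end group carried by compound 1 and compound 2.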